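Trifluoromethyl in place of nitro on the pendant ring

The source may report more compounds than this note shows. Statements on the series, on what has been measured and on what is new or still open speak of the compounds shown alone.

Compound 1, `O=c1c(-c2ccccc2[N+](=O)[O-])nc2ccccc2n1Cc1ccccc1`, in an assay on cells for activation of Cystic fibrosis transmembrane conductance regulator (Homo sapiens), read by fluorescence, with a stated time of 10 min; on this read-out lower numbers stand for an effect already at smaller amounts and higher numbers for an effect only at larger amounts of compound: 1000 nM
Compound 2, `O=c1c(-c2ccc([N+](=O)[O-])cc2)nc2ccccc2n1Cc1ccccc1`, in this assay : 1000 nM

Compound 2 stands level with compound 1 on the numbers shown; the single measured step, no change at the digits printed from compound 1 to compound 2 (within the scatter), lies within the scatter. Compound 3, `O=c1c(-c2ccc(C(F)(F)F)cc2)nc2ccccc2n1Cc1ccccc1`, arises by trifluoromethyl in place of nitro on an aromatic carbon. Going by the values given here, no measured step exchanges the nitro group for another group, so only the step from compound 1 to compound 2 bears on it, and it was flat. The step to compound 3 is therefore expected to be no change at the digits printed from compound 2 to compound 3 (within the scatter). Compound 3 is estimated at 1000 nM, within 400 nM to 3000 nM.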

Compound 3, half-maximal effective concentration: 1000 nM
Compound 3: middle estimate and measured number agree at the digits printed; the measured number falls inside the stated range.
By their numbers in this assay, from the lowest: compounds 1, 2 and 3 (each within the scatter of the next).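

In this assay, replacing nitro with trifluoromethyl gives no change at the digits printed from compound 2 to compound 3 (within the scatter), so at this place, para to a large group, the read-out does not depend on keeping the nitro group. The change also removes the hydrogen-bond acceptors counted for nitro without moving the value beyond the scatter. No available evidence bears on this result. On these data alone, whether an amine or a carboxylic acid at this place would hold the same level remains open. So does which change, if any, would shift the read-out beyond the scatter.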